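Acetamido on the Bare Phenyl of Compound 3

The compounds below may be only part of what the source reports. "The series", "measured", "known", "first", "only" and "open" are said of these compounds alone.

In a functional assay on NCI-H1975 cells (Homo sapiens) for cytotoxicity, read by MTT assay, with a stated time of 72 h (a higher number here means a weaker inhibitor, a lower number a stronger inhibitor), compound 1 `CC1CCN(c2ccc(Nc3ncc4nc(Nc5ccccc5)n(C5CCCC5)c4n3)cc2)CC1` gives 9800 nM, and compound 2 `OCCNc1ccc(Nc2ncc3nc(Nc4ccccc4)n(C4CCCC4)c3n2)cc1` gives 2810 nM. Compound 3 `c1ccc(Nc2ncc3nc(Nc4ccccc4)n(C4CCCC4)c3n2)cc1`, the unsubstituted parent, stands at > 10000 nM, which is a limit of the assay and not a number. Compound 4 `CC(=O)Nc1ccc(Nc2ncc3nc(Nc4ccccc4)n(C4CCCC4)c3n2)cc1` has acetamido in place of hydrogen on an aromatic carbon, para to a large group: acetamido in place of hydrogen on an aromatic carbon. Within the data shown here, two measured steps bear on this change. Swapping (2-hydroxyethyl)amino for hydrogen gave an at least 3.5-fold higher number from compound 2 to compound 3 (0.55 log units; beyond the scatter), and swapping 4-methylpiperidin-1-yl for hydrogen gave an at least 1.0-fold higher number from compound 1 to compound 3 (0.00 log units; that floor lies within the scatter). Going by these, the expected result in this assay is a modest move towards a lower number, an at least 2.0-fold lower number from compound 3 to compound 4 (0.30 log units; that floor lies within the scatter). For compound 4 the estimated value is 5000 nM, with an expected range from 2000 nM to 12000 nM.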

Compound 4, half-maximal inhibitory concentration: 1210 nM
Beside the measured number, compound 4's estimate is 4.1-fold (0.62 log units) above it, outside the stated range (below it).
By their numbers in this assay, from the lowest: compound 4; then compound 2; then compound 1. At a limit, above all of these: compound 3.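

Compound 3 is a limit of the assay and not a number: the limit of > 10000 nM in this assay, at which 1 of the 4 values shown sits. Even so, in this assay acetamido on this aromatic carbon gives an at least 8.2-fold lower number from compound 3 to compound 4 (0.91 log units; beyond the scatter) on a floor alone, so a group with no ring and only 4 heavy atoms is enough for a clear step here. It also outdoes both earlier substituents at this position, with a 2.3-fold lower number from compound 2 to compound 4 (0.37 log units; beyond the scatter) and an 8.1-fold lower number from compound 1 to compound 4 (0.91 log units; beyond the scatter) when it replaces them.

Which part of acetamido matters, the carbonyl or the amide hydrogen, stays open. So does the effect of a longer acyl chain, a sulfonamide or a carboxylic acid here.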